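Swapping Methoxy for Methylsulfanyl on Two Related Cores

The source may report more compounds than this note shows. Statements on the series, on what has been measured and on what is new or still open speak of the compounds shown alone.

Compound 1 `CSc1ccc(CNc2nc(SC)nc3ncccc23)cc1` and compound 2 `COc1ccc(CNc2nc(SC)nc3ncccc23)cc1` share one core, while compound 3 `COc1ccc(CNc2nc(SC)nc3ccccc23)cc1` is built on a second core; the difference between the two cores is not broken down here. In a functional assay on MCF7 cells (Homo sapiens) for cytotoxicity, read by MTT assay, with a stated time of 72 h (on this read-out higher numbers stand for lower toxicity in this test and lower numbers for higher toxicity in this test), compound 1 gives 9130 nM. In this assay compound 2 reaches only the limit of the assay, > 100000 nM, which is not a number. In this assay compound 3 also sits at the limit, > 100000 nM. The change methylsulfanyl in place of methoxy on an aromatic carbon produced an at least 10-fold lower number from compound 2 to compound 1 (1.03 log units; beyond the scatter). Compound 4 `CSc1ccc(CNc2nc(SC)nc3ccccc23)cc1` has not yet been measured; it differs from compound 3 by the same change, (methylsulfanyl in place of methoxy on an aromatic carbon). From compound 3 the step of an at least 5.0-fold lower number from compound 3 to compound 4 (0.69 log units; beyond the scatter) is expected. That expectation rests on an at least 10-fold lower number from compound 2 to compound 1 (1.03 log units; beyond the scatter) and on (the limit of > 100000 nM in this assay, at which 2 of the 3 values shown sit), which leaves the true size of the earlier step open. Compound 4 is therefore estimated at 20000 nM, between 5000 nM and 100000 nM.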

Compound 4, concentration lethal to 50% of the cells: > 100000 nM
Compound 4 gave a limit, no number (the forecaster's own chance of this, stated with the estimate: 30%); middle value at least 5.0-fold (0.69 log units) away from the limit.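

Compound 3 and compound 4 both end at a limit of the assay, not at a number, so no step can be read between them: the limit of > 100000 nM in this assay, at which 3 of the 4 values shown sit.

On these data alone, whether methylsulfanyl in place of methoxy lowers the number at all on the core of compound 3, as it does on the core of compound 1, stays open.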